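A few compounds are considered here, and "the series" means these few. Any claim that something is new, unique, unknown or untested is made for them only; others in the source may bear on it.

Compound 1 `CCCCC[Se]c1nc(NCc2ccccc2)c2ccccc2n1` and compound 2 `CCCCC[Se]c1nc(N)c2cccnc2n1` both carry a pentyl chain on selenium but have different cores; the difference between the two cores is not broken down here. In a functional assay on MCF7 cells (Homo sapiens) for cytotoxicity, read by MTT assay, with a stated time of 72 h (on this read-out lower numbers stand for higher toxicity in this test and higher numbers for lower toxicity in this test), compound 1 gives 99400 nM. In this assay compound 2 gives 85000 nM, a reading within the scatter of that for compound 1. Compound 3 `C[Se]c1nc(NCc2ccccc2)c2ccccc2n1` is compound 1 with the change (hydrogen in place of butyl on a saturated chain carbon bound to a selenium atom). For compound 3 this assay reports only a limit, > 100000 nM. The step of a number no lower from compound 1 to compound 3 (the limit leaves the size open) therefore leaves its size open, since the reading stops at the limit of > 100000 nM in this assay, at which 1 of the 3 values shown sits. Compound 4 `C[Se]c1nc(N)c2cccnc2n1` arises from compound 2 by the same change, (hydrogen in place of butyl on a saturated chain carbon bound to a selenium atom), at the same place. The step of a number no lower from compound 1 to compound 3 (the limit leaves the size open) gave a number no lower, and compound 2 starts at 85000 nM. On that footing the step of a 1.3-fold higher number from compound 2 to compound 4 (0.11 log units; within the scatter) is expected to run the same way, most likely ending again at the limit of this assay. Compound 4 is therefore estimated at 110000 nM, with a range expected from 65000 nM to 200000 nM.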

Compound 4, concentration lethal to 50% of the cells: > 100000 nM
Compound 4 ended at the assay's limit; the forecaster's own chance of this, stated with the estimate: 65%; the middle value does not contradict the limit.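

On the core of compound 2, replacing pentyl with methyl gives an at least 1.1-fold higher number from compound 2 to compound 4 (0.07 log units; that floor lies within the scatter) in this assay, and this is only a floor. Compound 4 reads > 100000 nM, which is a limit of the assay and not a number. Set beside the same change on the core of compound 1, the new step does not contradict the earlier one, but this shows only that the change can be carried to the second core without any sign of a conflict, and it does not show that its size carries over, as neither step can be read in full: the same change on two cores in this assay, a number no lower (the limit leaves the size open) from compound 1 to compound 3 and an at least 1.1-fold higher number (0.07 log units; that floor lies within the scatter) from compound 2 to compound 4; the limit leaves it open whether they differ.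

The compounds shown leave open how a propyl chain, or a chain longer than pentyl, on selenium would read in this assay on either core. They also leave open whether an amine or a carboxylic acid in place of the chain would bring the reading of either core clear of the limit.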